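The source may hold more compounds than are shown below. What is called first, only, known or untested is meant among the compounds shown, and "the series" means these compounds.

Measured so far:
Compound 1, `COc1cc2c(cc1CC=C(C)C)C(=O)C[C@@H](c1ccc(Oc3ccc(F)cc3)cc1)O2`: 37%
Compound 2, `COc1ccc([C@@H]2C/C(=N/OCc3cn(-c4ccc(C(=O)c5ccccc5)cc4)nn3)c3cc(CC=C(C)C)c(OC)cc3O2)cc1`: 41%

Both compounds were tested in a functional assay on MCF7 cells (Homo sapiens) for inhibition, read by sulforhodamine B assay, with a stated time of 48 h, tested at 50 uM; a lower number here means less inhibition of growth, a higher number more inhibition of growth at the concentration tested. Compound 2 stands at the top of these two numbers, yet the gap to compound 1 lies within the usual scatter, so no real difference between the two can be claimed from this assay.

Compound 3, `COc1ccc([C@@H]2C/C(=N/OCc3cn(-c4ccc(NC(C)=O)cc4)nn3)c3cc(CC=C(C)C)c(OC)cc3O2)cc1`, differs from compound 2 in one place only: acetamido in place of benzoyl on an aromatic carbon. Going by the values given here, no pair of measured compounds that differ by a single change is available here, so there is nothing to calibrate how much such a swap moves the number in this assay. Among the compounds with values here, with only two values, both of similar size, the most defensible expectation is a modest step. The expected step, a number 5 percentage points lower from compound 2 to compound 3 (within the scatter), is estimated to stay within the scatter, with no clear direction. Compound 3 is therefore expected to come in near 36%, within a range from 20% to 55%.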

Compound 3, percent growth inhibition at one concentration: 0%
For compound 3 the middle estimate is 36 percentage points above the measured one; the measured number lies below the stated range.
By their numbers in this assay, from the lowest: compound 3; then compounds 1 and 2 (each within the scatter of the next).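

Swapping benzoyl for acetamido on this aromatic carbon, para to a large group, brings a number 41 percentage points lower from compound 2 to compound 3 (beyond the scatter) in this assay and gives the first comparison here between compounds that differ in one place. The rest of the molecule stays the same, so this large fall can be tied to the exchange itself, which shows that the group at this position can strongly change growth inhibition at the concentration tested. The available information does not explain why the change has such a large effect.

A single pair cannot separate the loss of benzoyl from the arrival of acetamido. The compounds shown also leave open how an amine or a carboxylic acid at this position would compare, and whether any other group could match benzoyl here.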